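A few compounds are considered here, and "the series" means these few. Any claim that something is new, unique, unknown or untested is made for them only; others in the source may bear on it.

Compound 2, `NS(=O)(=O)c1ccc(NC(=S)Nc2ccc3ncnc(Nc4cccc(Cl)c4)c3c2)cc1`, was tested in a functional assay on NCI-H1975 cells (Homo sapiens) for antiproliferative activity, read by MTT assay, with a stated time of 72 h (on this read-out lower numbers stand for stronger inhibition and higher numbers for weaker inhibition), where compound 2 gives 39800 nM. Among the measured compounds shown here, only one other compound has been measured in this assay: compound 1, `C#Cc1cccc(Nc2ncnc3ccc(NC(=S)Nc4ccc(S(N)(=O)=O)cc4)cc23)c1`, which in this assay gives 13400 nM. For the measured compounds named here, compound 2 therefore stands with the highest of the two numbers, and the single measured step, a 3.0-fold higher number from compound 1 to compound 2 (0.47 log units; beyond the scatter), is the only guide available.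

Compound 3, `Cc1cccc(Nc2ncnc3ccc(NC(=S)Nc4ccc(S(N)(=O)=O)cc4)cc23)c1`, follows from compound 2 by methyl in place of chloro on an aromatic carbon. Going by the values given here, no measured step exchanges chloro for methyl here; the step from compound 1 to compound 2 touches the same aromatic carbon and was modest, which suggests that this position tolerates change without large swings. A step of about the same size or smaller, without a clear direction, is therefore expected; the expected step is a 1.3-fold lower number from compound 2 to compound 3 (0.12 log units; within the scatter). For compound 3 the estimate in this assay is 30000 nM, ranging from 10000 nM to 90000 nM.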

Compound 3, half-maximal inhibitory concentration: 35400 nM
Compound 3: the middle estimate sits 1.2-fold (0.07 log units) below what was measured, within the range that was stated.
By their numbers in this assay, from the lowest: compound 1; then compounds 3 and 2 (each within the scatter of the next).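

In this assay, chloro and methyl on this aromatic carbon could not be told apart, with the 3-chlorophenyl and 3-methylphenyl compounds lying within the scatter of each other (a 1.1-fold lower number from compound 2 to compound 3 (0.05 log units; within the scatter)). Ethynyl now stands apart from both groups, as methyl is also separated from it by a step beyond the scatter (a 2.6-fold higher number from compound 1 to compound 3 (0.42 log units; beyond the scatter)), so the gap seen earlier does not belong to chloro alone. No measurement at hand explains this result.

The three compounds leave open what an amine, a methoxy group or a longer chain would do on this carbon, and whether a nitrile would give a number like that of ethynyl. They also leave open how any of these groups would read elsewhere on this ring, as all three compounds carry theirs at the same place.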